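Fluoro to Hydrogen at the Aromatic Carbon of Compound 2

This account rests on a few compounds, and the source may have more. Where it says the series, first, only, none or still open, it means among the compounds named here.

Of the compounds shown here, two have so far been measured in an assay for inhibition of histone-lysine N-methyltransferase, H3 lysine-79 specific (Homo sapiens), read by scintillation counting, with stated times of 15 min and 60 min, tested at 50 uM, in the presence of a further agent that is not named here; a lower number here means a weaker effect, a higher number a stronger effect of the compound at the concentration tested. Compound 1, `Cc1occc1-c1nnc2sc(CCCc3ccccc3)nn12`, gives 17% in this assay. Compound 2, `Fc1ccc(-c2nnc3sc(/C=C/c4ccco4)nn23)cc1`, gives 44% in this assay, the higher of the two numbers, and its gap to compound 1 lies beyond the usual scatter of such measurements. For the measured compounds named here, the two compounds differ in more than one place, so their values show only that compound 2 is the stronger of the pair at the tested concentration.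

Compound 3, `C(=C/c1nn2c(-c3ccccc3)nnc2s1)\c1ccco1`, has not yet been measured. It differs from compound 2 by a single change, (hydrogen in place of fluoro on an aromatic carbon). Going by the values given here, no measured pair differing in exactly one place exists in this set, so the effect of the change cannot be read from a counterpart. The change is small, and a step no larger than the scatter, perhaps a slight loss, is expected; the step of a number 8 percentage points lower from compound 2 to compound 3 (within the scatter) is the one estimated here. Compound 3 is accordingly expected to give about 36% in this assay, with a range from 16% to 56%.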

Compound 3, a percentage reported as inhibition, at one concentration (the size of the read-out at that concentration, not a potency): 79%
Compound 3: the middle estimate sits 43 percentage points below what was measured; measured number outside the range, above it.
By their numbers in this assay, from the lowest: compound 1; then compound 2; then compound 3.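

Going from 4-fluorophenyl to phenyl, on a six-membered aromatic ring of carbon only and para to a large group, is the first change in this set that can be read in one place, and in this assay it appears as a number 35 percentage points higher from compound 2 to compound 3 (beyond the scatter), a large step. This position is therefore not a silent one: exchanging a single fluoro for hydrogen, with no ring, donor, acceptor or charge entering or leaving, moves the read-out well past the scatter, and here the compound with hydrogen gives the higher number. The earlier comparison of compound 1 with compound 2 could not show this, since those two differ in more than one place, and nothing available here explains the size or direction of the step.

The finding rests on a single pair, read at one concentration, so it gives no potency and leaves open whether the same exchange would have a similar effect in a compound with the other substituents of compound 1. It also leaves open how chloro, methoxy or an amine at this same position would compare with the hydrogen of compound 3.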